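The compounds below may be only part of what the source reports. "The series", "measured", "known", "first", "only" and "open" are said of these compounds alone.

Series notes. Compound 2 `Cc1c(C(=O)Nc2ccc(Oc3ccnc4[nH]ccc34)cc2)nnn1-c1ccccc1` in a functional assay on A549 cells (Homo sapiens) for cytotoxicity, read by MTT assay, with a stated time of 72 h (a higher number here means a weaker inhibitor, a lower number a stronger inhibitor), gives 420 nM. Among the compounds with values here, the only other measured compound, compound 1 `Cc1c(C(=O)Nc2ccc(Oc3ccnc4[nH]ccc34)c(F)c2)nnn1-c1ccccc1F`, in this assay gives 390 nM; the two numbers lie within the usual scatter of one another, so compound 2 stands level with compound 1 rather than apart from it. Compound 3 `Cc1c(C(=O)Nc2ccc(Oc3ccnc4[nH]ccc34)cc2)nnn1-c1ccccc1F` differs from compound 2 by fluoro in place of hydrogen on an aromatic carbon. Within the data shown here, no measured pair isolates this change. Given how close compound 1 and compound 2 sit in this assay, the step in this assay is expected to be small, a 1.1-fold lower number from compound 2 to compound 3 (0.02 log units; within the scatter), with no direction beyond the scatter. Compound 3 in this assay is therefore estimated at 400 nM, ranging from 200 nM to 800 nM.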

Compound 3, half-maximal inhibitory concentration: 320 nM
Estimate against measurement, compound 3: 1.3-fold (0.10 log units) above, and the stated range covers the measured number.
By their numbers in this assay, from the lowest: compounds 3, 1 and 2 (each within the scatter of the next).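

In this assay, phenyl to 2-fluorophenyl now has a measured step of its own (a 1.3-fold lower number from compound 2 to compound 3 (0.12 log units; within the scatter)), and the second fluoro of compound 1 can also be read alone, as hydrogen in place of fluoro (a 1.2-fold lower number from compound 1 to compound 3 (0.09 log units; within the scatter)). Each single replacement stays within the scatter, so fluoro on either aromatic carbon leaves the number in this assay unresolved from hydrogen. No measurement here offers an explanation for these small steps. Going by these compounds, whether a chloro, a methoxy or an amine on the same aromatic carbon would move the number beyond the scatter stays open.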